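The compounds below may be only part of what the source reports. "The series", "measured", "known", "first", "only" and "open" are said of these compounds alone.

Compound 1, `Nc1cc(N)c2nc(-c3ccccc3)c(Oc3ccc(F)cc3)nc2c1`, is the point of departure. In a functional assay on NCI/ADR-RES cells (Homo sapiens) for inhibition, read by sulforhodamine B assay, with a stated time of 48 h (on this read-out lower numbers stand for stronger inhibition of growth and higher numbers for weaker inhibition of growth), compound 1 gives 36300 nM, the lowest of the two numbers available. Compound 3, `COc1ccc(CNc2nc3cc(N)cc(N)c3nc2-c2ccccc2)cc1`, gives 83200 nM in this assay, a higher number whose gap to compound 1 lies beyond the usual scatter of the measurement. Compound 2, `CCOC(=O)[C@H](CCC(=O)O)NC(=O)c1ccc(CNc2nc3cc(N)cc(N)c3nc2-c2ccccc2)cc1`, is reported in this assay only as a limit of < 100000 nM and not as a number (the limit of < 100000 nM in this assay, at which 1 of the 3 values shown sits). Among the measured compounds shown here, the untested compound 4, `COc1ccc(Sc2nc3cc(N)cc(N)c3nc2-c2ccccc2)cc1`, differs from compound 1 in a single place: (4-methoxyphenyl)sulfanyl in place of 4-fluorophenoxy on an aromatic carbon No pair of measured compounds differs in one place, so the size of this change in this assay cannot be read from a measured step. For compound 4 the change is expected to shift the number only a little, with a slight drift toward weaker inhibition, an expected step of a 1.2-fold higher number from compound 1 to compound 4 (0.09 log units; within the scatter). Compound 4 is accordingly estimated to give 45000 nM in this assay, within a range from 15000 nM to 100000 nM.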

Compound 4, concentration for total growth inhibition: < 100000 nM
Compound 4: only a limit was reported (the forecaster's own chance of this, stated with the estimate: 20%); the middle value is on the limit's open side.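

Compound 4 is reported only as a limit, < 100000 nM, in this assay, so no step from compound 1 to compound 4 can be read, and compound 4 joins compound 2 at that limit: the limit of < 100000 nM in this assay, at which 2 of the 4 values shown sit.

The compounds shown leave open how far (4-methoxyphenyl)sulfanyl in place of 4-fluorophenoxy moves the number in this read-out.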